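This account rests on a few compounds, and the source may have more. Where it says the series, first, only, none or still open, it means among the compounds named here.

Among the compounds with values here, in a functional assay on A549 cells (Homo sapiens) for cytotoxicity, read by MTT assay, with a stated time of 48 h (on this read-out higher numbers stand for weaker inhibition and lower numbers for stronger inhibition), compound 3 `CCOC(=O)[C@@]1(C(=O)NCc2ccc(C)cc2)C[C@H]1c1cc(OC)c(OC)c(OC)c1` gives 17100 nM, the one single number in this small series. Compound 1 `CCOC(=O)[C@@]1(C(=O)Nc2ccccc2)C[C@@H]1c1cc(OC)c(OC)c(OC)c1` reaches a limit in this assay, > 100000 nM, and not a number. Compound 4 `CCOC(=O)[C@@]1(C(=O)Nc2ccccc2)C[C@H]1c1cc(OC)c(OC)c(OC)c1` keeps the configuration drawn for compound 3 and has phenyl in place of 4-methylbenzyl on an amide-type nitrogen. Compound 2 `CCOC(=O)C1(C(=O)Nc2ccccc2)CC1c1cc(OC)c(OC)c(OC)c1`, which also bears the anilino group, has two entries, 31500 nM; 48600 nM (2 entries). On that basis, a shift toward weaker inhibition is expected in this assay, though one no larger than the usual scatter. The estimated change is the step of a 1.8-fold higher number from compound 3 to compound 4 (0.24 log units; within the scatter). For compound 4 the expected value is 30000 nM, with an estimated range of 11000 nM to 85000 nM.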

Compound 4, half-maximal inhibitory concentration: 65900 nM
Beside the measured number, compound 4's estimate is 2.2-fold (0.34 log units) below it; the range from low to high includes it.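

In this assay, the change from 4-methylbenzyl to phenyl on an amide-type nitrogen now has a measured size and direction: a 3.9-fold higher number from compound 3 to compound 4 (0.59 log units; beyond the scatter). Compound 1 stands at a limit, > 100000 nM, and not a number. The change of configuration at the saturated ring carbon can be read only as a floor, an at least 1.5-fold lower number from compound 1 to compound 4 (0.18 log units; that floor lies within the scatter).

The compounds shown leave open whether plain benzyl or 4-methylphenyl on this nitrogen would read closer to compound 3 or to compound 4. They also leave open how a longer chain, such as 2-phenylethyl, would read there.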